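Swapping the aryl group on the distal piperazine nitrogen

The source may report more compounds than this note shows. Statements on the series, on what has been measured and on what is new or still open speak of the compounds shown alone.

Of the compounds shown here, two from the set have been measured in a functional assay on MCF7 cells (Homo sapiens) for cytotoxicity, read by MTT assay, with a stated time of 24 h; a higher number here means a weaker inhibitor, a lower number a stronger inhibitor. Compound 1, `Cc1ccc(-c2nnc(N3CCN(C(=O)CN4CCN(c5ccccc5Cl)CC4)CC3)nc2-c2ccc(C)cc2)cc1`, gives 859000 nM in this assay. Compound 2, `COc1cccc(N2CCN(CC(=O)N3CCN(c4nnc(-c5ccc(Cl)cc5)c(-c5ccc(Cl)cc5)n4)CC3)CC2)c1`, gives 149000 nM in this assay, the lower of the two numbers, and its gap to compound 1 lies beyond the scatter of repeated runs. Compound 3, `O=C(CN1CCN(c2ccc(Cl)cc2)CC1)N1CCN(c2nnc(-c3ccc(Cl)cc3)c(-c3ccc(Cl)cc3)n2)CC1`, has not yet been measured. It differs from compound 2 in one place: 4-chlorophenyl in place of 3-methoxyphenyl on an amine nitrogen in a ring. Going by the values given here, no measured pair shows this exact change, so its effect cannot be read off directly; the only other variation in the set, between compound 1 and compound 2, touches several positions at once and gives no clean reading of this single swap. The step in this assay from compound 2 to compound 3 is therefore expected to be small, likely within the scatter, with no firm direction, as a 1.2-fold higher number from compound 2 to compound 3 (0.08 log units; within the scatter). On that basis compound 3 is estimated to give about 180000 nM in this assay, with a plausible range from 60000 nM to 550000 nM.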

Compound 3, half-maximal inhibitory concentration: > 803000 nM
Compound 3: only a limit was reported (the forecaster's own chance of this, stated with the estimate: 10%); middle value at least 4.4-fold (0.64 log units) from the limit.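

In this assay compound 3 gives > 803000 nM, which is a limit and not a number. Going by these compounds alone, this is the first change in the set that touches one place alone, and 4-chlorophenyl in place of 3-methoxyphenyl on the amine nitrogen of the six-membered ring gives an at least 5.3-fold higher number from compound 2 to compound 3 (0.73 log units; beyond the scatter), so the aryl group at this position does move the read-out, here towards a weaker inhibitor. The step fixes only a lower bound on that move, and its true size remains unknown, with the bound resting on a single reading: the limit of > 803000 nM in this assay, at which 1 of the 3 values shown sits.

The compounds shown leave open whether the step follows from the chlorine, from the loss of the methoxy group, or from where the substituent sits on the phenyl ring, and 4-methoxyphenyl and 3-chlorophenyl would be the groups to separate these. They also do not show how an unsubstituted phenyl, a pyridine ring or a small alkyl group would read at this nitrogen, nor whether the 3-methoxyphenyl of compound 2 is the best choice here.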